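Anilide aryl swap: chloro to benzyl in the oxalamide series

The compounds below may be only part of what the source reports. "The series", "measured", "known", "first", "only" and "open" are said of these compounds alone.

Of the compounds shown here, two carry numbers so far. Compound 1 `C[C@H](NC(=O)C(=O)Nc1ccccn1)C(=O)N[C@@H](CC(=O)O)C(=O)COc1c(F)c(F)cc(F)c1F` gives 200 nM in a functional assay on THP-1 cells (Homo sapiens) for inhibition; on this read-out lower numbers stand for stronger inhibition and higher numbers for weaker inhibition. Among the compounds with values here, compound 2 `C[C@H](NC(=O)C(=O)Nc1ccccc1Cl)C(=O)N[C@@H](CC(=O)O)C(=O)COc1c(F)c(F)cc(F)c1F` gives 540 nM in this assay, the higher of the two numbers; the only step known, a 2.7-fold higher number from compound 1 to compound 2 (0.43 log units; beyond the scatter), is the swap from pyridin-2-yl to 2-chlorophenyl on the amide-type nitrogen, and it leaves compound 2 at the weaker end of what has been measured.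

Compound 3 `C[C@H](NC(=O)C(=O)Nc1ccccc1Cc1ccccc1)C(=O)N[C@@H](CC(=O)O)C(=O)COc1c(F)c(F)cc(F)c1F` keeps the shared core and the phenyl on the amide-type nitrogen but changes the substituent on that phenyl: benzyl in place of chloro on an aromatic carbon. Within the data shown here, no measured step exchanges one substituent for another on this ring; the step from compound 1 to compound 2 exchanges the whole ring and bears on the present change only loosely, showing that variation at this position moves the number modestly. The direction for a benzyl in place of chloro cannot be read from the two numbers in hand. A step of modest size, in either direction, is the most that is expected, so a 1.3-fold higher number from compound 2 to compound 3 (0.11 log units; within the scatter) is the estimated step from compound 2 to compound 3 in this assay. Compound 3 is therefore expected to give about 700 nM in this assay, with a range from 200 nM to 2500 nM.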

Compound 3, half-maximal inhibitory concentration: 540 nM
Estimate against measurement, compound 3: 1.3-fold (0.11 log units) above; the measured number falls inside the stated range.
By their numbers in this assay, from the lowest: compound 1; then compounds 2 and 3 (each within the scatter of the next).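

In this assay, benzyl in place of chloro on an aromatic carbon gives no change at the digits printed from compound 2 to compound 3 (within the scatter), so this exchange, the first among the compounds shown to change a substituent on this ring rather than the ring itself, leaves the read-out flat even though the entering group brings seven heavy atoms and an aromatic ring of its own where chloro has a single atom. Set against a 2.7-fold higher number from compound 1 to compound 2 (0.43 log units; beyond the scatter), which lies beyond the scatter, the series so far shows a measurable step for the exchange of the whole ring and none for this exchange of substituent, a contrast that rests on only these three compounds. Nothing on hand accounts for the flat step.

Open, as far as these compounds go, is whether this insensitivity holds for groups that carry hydrogen-bond donors or acceptors or a net charge, such as an aminomethyl group or a carboxylic acid on the same aromatic carbon, since chloro and benzyl have neither. Also open, from the compounds shown here alone, is whether a longer chain, such as phenethyl, would keep the number where compound 2 and compound 3 stand.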